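Extending the Phenolic Oxygen of Compound 2

The source may report more compounds than this note shows. Statements on the series, on what has been measured and on what is new or still open speak of the compounds shown alone.

Compound 1 `CC(C)=CCC1Cc2c(O)cc(=O)n(CCCO)c2CC1(C)C`: 25.6%
Compound 2 `CC(C)=CCC/C(C)=C/CC1Cc2c(O)cc(=O)n(CCCO)c2CC1(C)C`: 28.7%
Compound 3 `CC(C)=CCC1Cc2c(OC(=O)Nc3ccc(F)c(Cl)c3)cc(=O)n(CCCO)c2CC1(C)C`: 79.8%

In a functional assay on PANC-1 cells (Homo sapiens) for inhibition, read by MTT assay, with a stated time of 24 h, tested at 10 uM (a lower number here means less inhibition, a higher number more inhibition at the concentration tested (going by the name of the read-out)), compound 2 gives 28.7%, the second highest of the three numbers. Compound 1 sits nearest, the step of a number 3.1 percentage points higher from compound 1 to compound 2 (within the scatter). Compound 3 stands furthest, the step of a number 54.2 percentage points higher from compound 1 to compound 3 (beyond the scatter).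

Compound 4 `CC(C)=CCC/C(C)=C/CC1Cc2c(OCCCNC(=O)c3ccco3)cc(=O)n(CCCO)c2CC1(C)C` differs from compound 2 by 3-(((furan-2-yl)carbonyl)amino)propyl in place of hydrogen on an oxygen on an aromatic ring. Among the compounds with values here, the one measured step that touches this oxygen, a number 54.2 percentage points higher from compound 1 to compound 3 (beyond the scatter), shows that replacing its hydrogen can raise inhibition strongly, though the entering group there was a carbamoyl rather than a chain carrying a furan amide. A rise beyond the scatter is therefore expected for compound 4, but with wide uncertainty about its size. The expected step is a number 26.3 percentage points higher from compound 2 to compound 4 (beyond the scatter), and compound 4 is estimated at 55%, within 30% to 80%.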

Compound 4, a percentage reported as inhibition, at one concentration (the size of the read-out at that concentration, not a potency): 69.5%
Estimate against measurement, compound 4: 14.5 percentage points below; low and high end bracket the measured number.
By their numbers in this assay, from the lowest: compounds 1 and 2 (each within the scatter of the next); then compound 4; then compound 3.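

In this assay, replacing the hydrogen on this oxygen gives a number a number 40.8 percentage points higher from compound 2 to compound 4 (beyond the scatter), so a large rise now appears with a second entering group and on the chain of compound 2, not only on that of compound 1. Compound 3 and compound 4 differ in more than one place, so their two entering groups cannot be ranked against each other. Nothing available explains the rise. As far as these compounds go, it remains open which part of the 3-(((furan-2-yl)carbonyl)amino)propyl group carries the rise. A plain propyl group, a thiophene in place of the furan, or a longer chain would help separate those parts.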